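Compound 3: hydrogen in place of methoxymethyl

This account rests on a few compounds, and the source may have more. Where it says the series, first, only, none or still open, it means among the compounds named here.

compound 1 `COc1ccc(C2=C(c3cc(OC)c(OC)c(OC)c3)C(=O)CC2O[SiH2]C(C)(C)C)cc1OC`: > 100 ug/mL (a limit of the assay)
compound 2 `COCOc1cc(C2=C(c3cc(OC)c(OC)c(OC)c3)C(=O)CC2O[SiH2]C(C)(C)C)ccc1OC`: 40 ug/mL

Within the data shown here, in an ADME assay on ECV-304 cells (Homo sapiens) for cytotoxicity, read by MTT assay, with a stated time of 72 h (a lower number here means a stronger inhibitor, a higher number a weaker inhibitor), compound 2 gives 40 ug/mL, the only actual number so far. Compound 1 sits at the limit of > 100 ug/mL in this assay, at which 1 of the 2 values shown sits, which is a limit and not a number.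

The next entry is compound 3 `COc1ccc(C2=C(c3cc(OC)c(OC)c(OC)c3)C(=O)CC2O[SiH2]C(C)(C)C)cc1O`, which keeps the shared core and carries hydrogen in place of methoxymethyl on an oxygen on an aromatic ring. Among the measured compounds shown here, one measured step bears on this, as it changes the group on the same oxygen: an at least 2.5-fold lower number from compound 1 to compound 2 (0.39 log units; beyond the scatter). That step starts from a limit, so its true size is not known. It shows that the group on this oxygen can move the number in this assay, but neither compound 1 nor compound 2 carries a free hydroxy, so it gives no firm direction for the new change. The estimate therefore stays close to compound 2, with a wide range on both sides. The expected change is a 1.3-fold lower number from compound 2 to compound 3 (0.12 log units; within the scatter), a small lowering that is estimated with little confidence. For compound 3 the estimated value is 30 ug/mL, with an expected range of 8 ug/mL to 100 ug/mL.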

Compound 3, half-maximal inhibitory concentration: 30 ug/mL
Compound 3: middle estimate and measured number agree at the digits printed; the range from low to high includes it.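

Working notes on the group on this oxygen, read in this assay. With hydrogen in place of methoxymethyl, the step is a 1.3-fold lower number from compound 2 to compound 3 (0.12 log units; within the scatter), so the free hydroxy of compound 3 and the methoxymethoxy of compound 2 cannot be told apart here, and the masking group on this oxygen is not needed for the value seen in compound 2. The comparison with methyl on the same oxygen gives an at least 3.3-fold lower number from compound 1 to compound 3 (0.52 log units; beyond the scatter), which places the methyl of compound 1 apart from both the hydroxy and the methoxymethoxy among these three compounds. The value of compound 1 is a limit and not a number, so the full size of this step and of the earlier one stays unknown: the limit of > 100 ug/mL in this assay, at which 1 of the 3 values shown sits.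

The compounds shown leave open whether the separation of compound 1 holds for other small groups on this oxygen, such as ethyl or a longer chain, or for a chain ending in an amine or a carboxylic acid. They also give no reading of how much of the value of compound 3 depends on the oxygen itself, as an amine in its place would test.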